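Swapping ethyl for cyclobutyl on a weak amide analogue

The source may hold more compounds than are shown below. What is called first, only, known or untested is meant among the compounds shown, and "the series" means these compounds.

Measured so far:
- compound 1 `C=CC(=O)Nc1cc(N)nc(Sc2c(OCC)nc(N3CCN(C)CC3)nc2OCC)n1`: 1.1 uM
- compound 2 `C=CC(=O)Nc1ccnc(Sc2c(C)nc(N3CCN(C)CC3)nc2C)n1`: 1.8 uM
- compound 3 `CCC(=O)Nc1cccc(Sc2c(OC)nc(N3CCN(C)CC3)nc2OC)c1`: 55 uM

Of the compounds shown here, three have been tested in a functional assay on SK-BR-3 cells (Homo sapiens) for cytotoxicity, read by resazurin assay, with a stated time of 72 h; on this read-out higher numbers stand for weaker inhibition of growth and lower numbers for stronger inhibition of growth. Compound 1 gives 1.1 uM and compound 2 gives 1.8 uM in this assay, both well beyond the usual scatter from the value of compound 3, which in this assay gives 55 uM. Compound 3 therefore has the highest number of the three, that is, the weakest growth inhibition. Among the compounds with values here, compounds 1 and 2 differ from compound 3 in several places at once, so no single step between them can be read from these data; only their values can be set side by side.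

The next compound, compound 4 `COc1nc(N2CCN(C)CC2)nc(OC)c1Sc1cccc(NC(=O)C2CCC2)c1`, keeps the whole of compound 3 except for one change: cyclobutyl in place of ethyl on a carbonyl carbon. The amide that links this group to the ring is unchanged, and no donor or acceptor is added or lost. Within the data shown here, no measured pair shows what such a change does in this assay, so there is no step to lean on.

The step from compound 3 to compound 4 is expected to be small, a 1.2-fold lower number from compound 3 to compound 4 (0.09 log units; within the scatter), within the scatter and of uncertain direction. Compound 4 is estimated to give 45 uM in this assay, with a range of 18 uM to 120 uM.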

Compound 4, concentration for growth inhibition (reported as GI): 70 uM
Beside the measured number, compound 4's estimate is 1.6-fold (0.19 log units) below it; measured number inside the range.
By their numbers in this assay, from the lowest: compounds 1 and 2 (each within the scatter of the next); then compounds 3 and 4 (each within the scatter of the next).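

In this assay, within the data shown here, cyclobutyl in place of ethyl on a carbonyl carbon gives a 1.3-fold higher number from compound 3 to compound 4 (0.10 log units; within the scatter), which makes this the first comparison here in which only one place differs. At this position, the open ethyl chain and the four-membered carbon ring therefore cannot be told apart by growth inhibition, so this swap of one carbon group for another leaves the read-out unchanged within ordinary measurement noise. No supporting evidence accompanies this pair that could explain the result.

The compounds shown leave open whether a group of a different kind on this carbonyl, such as a dimethylaminomethyl group, or a longer chain such as hexyl, would shift the number beyond the scatter. One pair also cannot show whether cyclobutyl and ethyl would read alike on a different core, so the finding applies only to the core shared by compound 3 and compound 4.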